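Methoxy in place of chloro: expectation for compound 3

This account rests on a few compounds, and the source may have more. Where it says the series, first, only, none or still open, it means among the compounds named here.

In a functional assay on HSC-4 cells (Homo sapiens) for cytotoxicity, with a stated time of 24 h (a higher number here means that more compound is tolerated, a lower number that less compound is tolerated), compound 1 `O=C1/C(=C/c2ccc(F)cc2)CCC/C1=C\c1cccc([N+](=O)[O-])c1` gives 2500 nM and compound 2 `O=C1/C(=C/c2ccc(Cl)cc2)CCC/C1=C\c1cccc([N+](=O)[O-])c1` gives 2300 nM. Within the data shown here, compound 2 therefore stands level with compound 1, the only other measured compound. Compound 3 `COc1ccc(/C=C2\CCC/C(=C\c3cccc([N+](=O)[O-])c3)C2=O)cc1` has methoxy in place of chloro on an aromatic carbon, para to a large group: methoxy in place of chloro on an aromatic carbon. Among the measured compounds shown here, only one measured step bears on this change: a 1.1-fold lower number from compound 1 to compound 2 (0.04 log units; within the scatter), for chloro in place of fluoro. For the measured compounds named here, that step covers two halogens only, and no measured compound carries methoxy, so it is weak support and the range is kept wide. No step beyond the scatter is expected, and no direction is firmly indicated. The expected step is a 1.2-fold lower number from compound 2 to compound 3 (0.06 log units; within the scatter). In this assay, the estimate for compound 3 is 2000 nM, with an expected range of 800 nM to 4500 nM.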

Compound 3, half-maximal cytotoxic concentration: 11000 nM
The estimate for compound 3 lay 5.5-fold (0.74 log units) below the measured number, outside the stated range (above it).
By their numbers in this assay, from the lowest: compounds 2 and 1 (each within the scatter of the next); then compound 3.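

In this assay, among these compounds, the change from 4-chlorophenyl to 4-methoxyphenyl gives the first step at this position beyond the scatter (a 4.8-fold higher number from compound 2 to compound 3 (0.68 log units; beyond the scatter)). Methoxy in place of fluoro reads the same way (a 4.4-fold higher number from compound 1 to compound 3 (0.64 log units; beyond the scatter)), so more compound is tolerated with methoxy than with either halogen, while the two halogens stand level with each other. The number at this position therefore does respond to the group placed there, but nothing available explains the step.

As far as these compounds go, it remains open whether the higher number is specific to methoxy or extends to other groups at this position, such as an amine, a hydroxyl or a longer alkoxy chain. From the compounds shown here alone, the other aromatic ring, with its nitro group, is the same in all three compounds, so it is also open whether the step holds with a different group there.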